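A Sulfamoyl Group Enters: Cytotoxicity Expected for Compound 3

The source may hold more compounds than are shown below. What is called first, only, known or untested is meant among the compounds shown, and "the series" means these compounds.

Compound 1 `Fc1ccc2nc(-c3cc(-c4ccccc4)nn3-c3ccccc3)ccc2c1` and compound 2 `Fc1ccc(-c2cc(-c3ccc4cc(F)ccc4n3)n(-c3ccccc3)n2)cc1` have both been tested in an ADME assay on Huh-7 cells (Homo sapiens) for cytotoxicity, read by XTT assay, with a stated time of 3 days, tested at 200 uM; on this read-out higher numbers stand for a weaker effect at the one concentration tested and lower numbers for a stronger effect. In this assay compound 1 gives 98.3%, and compound 2 gives 87.5%. For the measured compounds named here, the single measured step, a number 10.8 percentage points lower from compound 1 to compound 2 (beyond the scatter), leaves compound 2 as the lowest of the two numbers, with compound 1 the nearest. Compound 3 `NS(=O)(=O)c1ccc(-n2nc(-c3ccc(F)cc3)cc2-c2ccc3cc(F)ccc3n2)cc1` remains to be measured in this assay. It differs from compound 2 by sulfamoyl in place of hydrogen on an aromatic carbon. Going by the values given here, no measured step involves a sulfamoyl group; the only known step concerns fluoro in place of hydrogen and was modest. The scale also has little room upward, and compound 2 already sits near its top. Compound 3 is therefore expected to show a step of a number 2.5 percentage points higher from compound 2 to compound 3 (within the scatter), not beyond the scatter. The estimate for compound 3 in this assay is 90%, with a range from 75% to 98%.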

Compound 3, a percentage reported as activity, at one concentration (the size of the read-out at that concentration, not a potency): 43%
The estimate for compound 3 lay 47 percentage points above the measured number; measured number below the stated range.
By their numbers in this assay, from the lowest: compound 3; then compound 2; then compound 1.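

The change from phenyl to 4-sulfamoylphenyl, para to a large group, gives a number 44.5 percentage points lower from compound 2 to compound 3 (beyond the scatter) in this assay, far larger than the modest fluoro step, a number 10.8 percentage points lower from compound 1 to compound 2 (beyond the scatter). This place on the shared core can therefore carry a large shift in the read-out, and compound 3, at 43%, moves well away from the top of the scale where compound 2 and compound 1 sit. No available evidence bears on what lies behind this shift.

The compounds shown leave open whether the shift belongs to the sulfamoyl group as a whole or to one part of it, a question that a methylsulfonyl group or a carboxylic acid at the same place could address. They also leave open whether a smaller group there, such as an amine, would move the read-out at all.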